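Urea aryl halogen variation on the shared core

The source may report more compounds than this note shows. Statements on the series, on what has been measured and on what is new or still open speak of the compounds shown alone.

Measured so far in a functional assay on MKN-45 cells (Homo sapiens) for cytotoxicity, read by MTT assay, with a stated time of 72 h; on this read-out higher numbers stand for weaker inhibition and lower numbers for stronger inhibition:
- compound 1 `CN(C)CCNc1nc(-c2ccc(NC(=O)Nc3ccccc3)cc2)nc2ccsc12`: 1120 nM
- compound 2 `CN(C)CCNc1nc(-c2ccc(NC(=O)Nc3ccc(F)cc3)cc2)nc2ccsc12`: 330 nM
- compound 3 `CN(C)CCNc1nc(-c2ccc(NC(=O)Nc3ccccc3F)cc2)nc2ccsc12`: 530 nM

Compound 3 sits second highest of the three numbers in this assay. Its nearest neighbour is compound 2, and the step of a 1.6-fold higher number from compound 2 to compound 3 (0.21 log units; within the scatter) is within the scatter, so the two cannot be ordered. Its furthest neighbour is compound 1, and the step of a 2.1-fold lower number from compound 1 to compound 3 (0.32 log units; beyond the scatter) is beyond the scatter.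

Compound 4 `CN(C)CCNc1nc(-c2ccc(NC(=O)Nc3ccc(Cl)cc3)cc2)nc2ccsc12` is the next step. The change is 4-chlorophenyl in place of 2-fluorophenyl on an amide-type nitrogen. For the measured compounds named here, two measured steps bear on halogen on that ring: a 3.4-fold lower number from compound 1 to compound 2 (0.53 log units; beyond the scatter) and a 2.1-fold lower number from compound 1 to compound 3 (0.32 log units; beyond the scatter), both fluoro in place of hydrogen and both modest lowerings. The step of a 1.6-fold higher number from compound 2 to compound 3 (0.21 log units; within the scatter) shows that moving the fluorine between the two measured positions makes no difference beyond the scatter. Going by the values given here, no chloro analogue has been measured, so the size of a chlorine effect is unknown here.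

Compound 4 is therefore expected to land close to compound 2, with a 1.8-fold lower number from compound 3 to compound 4 (0.25 log units; within the scatter) as the expected step. The estimate for compound 4 in this assay is 300 nM, expected to fall between 110 nM and 800 nM.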

Compound 4, half-maximal inhibitory concentration: 250 nM
Beside the measured number, compound 4's estimate is 1.2-fold (0.08 log units) above it, within the range that was stated.
By their numbers in this assay, from the lowest: compounds 4, 2 and 3 (each within the scatter of the next, the first and the last beyond it); then compound 1.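

In this assay, for the compounds shown here, chloro is the first halogen other than fluoro on this ring, and it keeps the gain over the phenyl of compound 1: a 4.5-fold lower number from compound 1 to compound 4 (0.65 log units; beyond the scatter) is the largest step from that compound so far. Chloro in place of fluoro on the same aromatic carbon gives a 1.3-fold lower number from compound 2 to compound 4 (0.12 log units; within the scatter) and so does not separate the two halogens, while a 2.1-fold lower number from compound 3 to compound 4 (0.33 log units; beyond the scatter) is beyond the scatter but changes both the halogen and its place on the ring. Nothing available explains these steps.

Still open, from the compounds shown here alone, is whether bromo, methyl, methoxy or a carboxylic acid in place of the chloro of compound 4 would hold these numbers. Also open, going by these compounds, is whether chloro where compound 3 carries its fluoro would give the same rise that fluoro shows there.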